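A few compounds are considered here, and "the series" means these few. Any claim that something is new, unique, unknown or untested is made for them only; others in the source may bear on it.

Series notes, step from compound 1 to compound 4.

Compound 1 `Cc1ncsc1C(=O)NCCC1CCN(S(=O)(=O)NC(=O)NC[C@@H]2C[C@@H]3C=C[C@@H]2C3)CC1` gives 25% in a functional assay on the whole organism (blood) with Rattus norvegicus as the target, with stated times of 24 h and 1 h, at a dose of 15 mg/kg by the intraperitoneal route; a lower number here means a weaker effect, a higher number a stronger effect of the compound at the dose given. Going by the values given here, it holds the second highest of the three numbers measured so far. Compound 3 `Cn1cc(C(=O)NCCC2CCN(S(=O)(=O)NC(=O)NC3CCCCC3)CC2)c(=O)n(C)c1=O` gives 15% in this assay; the gap between compound 1 and compound 3 lies within the scatter, so the two are not ordered. Compound 2 `O=C(NC[C@@H]1C[C@@H]2C=C[C@@H]1C2)NS(=O)(=O)N1CCC(CCNC(=O)c2cscn2)CC1` gives 37% in this assay, and the step of a number 12 percentage points higher from compound 1 to compound 2 (beyond the scatter) is beyond the scatter and modest in size.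

Compound 4 `O=C(NC[C@@H]1C[C@@H]2C=C[C@@H]1C2)NS(=O)(=O)N1CCC(CCNC(=O)c2nc3ccccc3s2)CC1` has not been measured in this assay. It differs from compound 1 in one place: 1,3-benzothiazol-2-yl in place of 4-methyl-1,3-thiazol-5-yl on a carbonyl carbon. Among the compounds with values here, the only measured step that touches the same place is the one from compound 1 to compound 2, where a different aromatic group on the same carbonyl carbon gave the modest rise just described. Within the data shown here, no measured pair shows the benzothiazole group itself, so the size of the change cannot be read directly; the one comparable step points upward.

On that basis compound 4 is expected to show a step of a number 7 percentage points higher from compound 1 to compound 4 (within the scatter) in this assay, upward but uncertain in size. The estimate for compound 4 in this assay is 32%, with a range from 17% to 47%.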

Compound 4, a percentage reported as activity, at one dose (the size of the read-out at that dose, not a potency): 34%
Beside the measured number, compound 4's estimate is 2 percentage points below it, within the range that was stated.
By their numbers in this assay, from the lowest: compounds 3, 1, 4 and 2 (each within the scatter of the next, the first and the last beyond it).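

In this assay, 1,3-benzothiazol-2-yl on the carbonyl carbon gives a number 9 percentage points higher from compound 1 to compound 4 (within the scatter) against 4-methyl-1,3-thiazol-5-yl, and a number 3 percentage points lower from compound 2 to compound 4 (within the scatter) against 1,3-thiazol-4-yl. This position therefore accepts the added six-membered aromatic ring of carbon only with no step beyond the scatter from either thiazole compound, something the two thiazole compounds alone could not show, and the benzothiazole cannot be grouped with one thiazole rather than the other. Nothing measured here bears on why the read-out behaves this way at this position.

On these data alone, it remains open how a plain phenyl ring, a saturated ring such as cyclohexyl, or a benzothiazole carrying a carboxylic acid or an amine would read on the same carbonyl carbon, and so whether any aromatic ring is needed there at all. Each compound also has a read-out at a single dose, so whether the small differences among these aromatic groups would persist at other doses also stays unresolved.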